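A few compounds are considered here, and "the series" means these few. Any claim that something is new, unique, unknown or untested is made for them only; others in the source may bear on it.

Compound 1 `COC(=O)c1ccc(NCc2cncn2Cc2ccccc2-c2ccccc2)cc1-c1ccccc1`: "not determined" (no result reported)
Compound 2 `COC(=O)c1ccc(NCc2cncn2Cc2cccc(F)c2)cc1-c1ccccc1`: > 1000 nM
Compound 3 `COC(=O)c1ccc(NCc2cncn2Cc2cccc(Cl)c2)cc1-c1ccccc1`: > 10000 nM

These results come from a toxicity assay on NIH3T3 cells (Mus musculus) for cytotoxicity, read by resazurin assay; a higher number here means that more compound is needed for the effect, a lower number that less compound is needed. Compound 3 gives only a limit, > 10000 nM. Compound 2 also gives only a limit, > 1000 nM. Compound 4 `COC(=O)c1ccc(NCc2cncn2Cc2cccc(C(C)(C)C)c2)cc1-c1ccccc1` has tert-butyl in place of chloro on an aromatic carbon, meta to a large group: tert-butyl in place of chloro on an aromatic carbon. Going by the values given here, the one measured step that bears on this, a step that the two limits leave unreadable from compound 2 to compound 3, also exchanged a group on an aromatic carbon, but it gives no size to carry over. No change beyond the scatter is therefore expected in this assay, and the estimated step is a number no higher from compound 3 to compound 4 (the limit leaves the size open). The value expected for compound 4 is 10000 nM, estimated to lie between 2500 nM and 30000 nM.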

Compound 4, half-maximal effective concentration: > 1000 nM
Compound 4: a limit, no number; the forecaster's own chance of this, stated with the estimate: 65%; the middle value lies beyond the limit too.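

Going by these compounds alone, compound 2, compound 3 and compound 4 all give only limits in this assay, so no step among them can be read. The compounds shown leave open whether fluoro, chloro and tert-butyl differ in this assay at all.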